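This account rests on a few compounds, and the source may have more. Where it says the series, first, only, none or still open, it means among the compounds named here.

The shared core carries a hydrazone whose nitrogen bears an aryl group, and the dose needed in a functional assay on the whole organism with Rattus norvegicus as the target (a lower number here means that less compound is needed, a higher number that more compound is needed for the effect), is the only measure at hand. Among the measured compounds shown here, compound 1, `CC1CCC(=NNc2ccccc2)c2ncc(C(=O)O)c(=O)n21`, gives in this assay a dose of 1.2 umol/kg, the single number among the two values shown. Compound 2, `CC1CCC(=NNc2ccccc2C(=O)O)c2ncc(C(=O)NO)c(=O)n21`, differs in more than one place and returns in this assay only > 100 umol/kg, a limit of the assay rather than a number, as noted in the limit of > 100 umol/kg in this assay, at which 1 of the 2 values shown sits. Compound 3, `CC1CCC(=NNc2cc(Cl)cc(Cl)c2)c2ncc(C(=O)O)c(=O)n21`, is not yet measured and differs from compound 1 in a single place: 3,5-dichlorophenyl in place of phenyl on an amine nitrogen. For the measured compounds named here, no measured pair describes this kind of change, so the step of a 1.7-fold higher number from compound 1 to compound 3 (0.22 log units; within the scatter) is only an expectation, and it is expected to stay small, within or just beyond the usual scatter, leaning toward a slightly higher dose. Compound 3 is accordingly estimated at 2 umol/kg, with a range from 0.5 umol/kg to 8 umol/kg.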

Compound 3, dose for 50% inhibition: > 100 umol/kg
Compound 3 ended at the assay's limit; the forecaster's own chance of this, stated with the estimate: 10%; at least 50-fold (1.69 log units) between middle value and limit.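

With the rest of the structure unchanged, 3,5-dichlorophenyl in place of phenyl on an amine nitrogen brings an at least 83-fold higher number from compound 1 to compound 3 (1.92 log units; beyond the scatter). In this assay, from the compounds shown here alone, compound 3 gives > 100 umol/kg, a limit of the assay and not a number, so the full size of the step stays unknown. Compound 2 differs from compound 1 in more than one place, which makes this the first single change that can be read at this position, and it shows that the aryl group here cannot be altered freely, with the limit now shared: the limit of > 100 umol/kg in this assay, at which 2 of the 3 values shown sit.

Going by these compounds, it remains open whether a single chlorine, a fluorine or a methoxy group on the phenyl ring would keep the dose near that of compound 1 at 1.2 umol/kg. The compounds shown also do not tell what lies behind the step, or whether the same change would act alike with an ester in place of the carboxylic acid.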